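A few compounds are considered here, and "the series" means these few. Any claim that something is new, unique, unknown or untested is made for them only; others in the source may bear on it.

Measured compounds:
Compound 1 `COc1cc(OC)c2c(=O)cc(-c3ccc(OCc4cn(-c5ccc(Cl)cc5)nn4)c(OC)c3)oc2c1` gives, in an ADME assay on Huh-7 cells (Homo sapiens) for cytotoxicity, read by MTT assay, with a stated time of 72 h (on this read-out lower numbers stand for higher toxicity in this test and higher numbers for lower toxicity in this test), a value reported only as a limit of the assay, > 100 ug/mL.
Compound 2 `COc1cc(OC)c2c(=O)cc(-c3ccc(OCc4cn(-c5ccc(F)c(Cl)c5)nn4)c(OC)c3)oc2c1` gives in this assay likewise a limit, > 100 ug/mL.
Compound 3 `COc1cc(O)c(C(=O)/C=C/c2ccc(OCc3cn(-c4ccc(F)c(Cl)c4)nn3)c(OC)c2)c(OC)c1` gives in this assay likewise a limit, > 100 ug/mL.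

Compounds 1 and 2 share one core; compound 3 carries a different core, and the difference between the two cores is not broken down here. Between compound 2 and compound 1 the change is 4-chlorophenyl in place of 3-chloro-4-fluorophenyl on an aromatic nitrogen, and the corresponding step in this assay, a step that the two limits leave unreadable from compound 2 to compound 1, cannot be read in size because the limit of > 100 ug/mL in this assay, at which 3 of the 3 values shown sit, holds for both of them. No step is listed from compound 2 to compound 3; their two values show only that each sits at that limit.

Compound 4 `COc1cc(O)c(C(=O)/C=C/c2ccc(OCc3cn(-c4ccc(Cl)cc4)nn3)c(OC)c2)c(OC)c1` is not yet measured. It differs from compound 3 by 4-chlorophenyl in place of 3-chloro-4-fluorophenyl on an aromatic nitrogen, which is the same change as that from compound 2 to compound 1, with the place described in identical words.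

For this assay the step from compound 3 to compound 4 is expected to be small, a step that the limit leaves unreadable from compound 3 to compound 4, which rests on the measured pair, where the same change left both compound 2 and compound 1 at the limit, (the limit of > 100 ug/mL in this assay, at which 3 of the 3 values shown sit), and on compound 3 itself sitting at that limit with > 100 ug/mL. Compound 4 is therefore estimated at 150 ug/mL, with a range from 70 ug/mL to 400 ug/mL, and most likely the assay will again report only a limit.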

Compound 4, half-maximal cytotoxic concentration: > 100 ug/mL
Compound 4 ended at the assay's limit (the forecaster's own chance of this, stated with the estimate: 85%); the middle value does not contradict the limit.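

The step from compound 3 to compound 4 in this assay cannot be read in size, because both values are limits of the assay and not numbers: the limit of > 100 ug/mL in this assay, at which 4 of the 4 values shown sit.

Left open is whether the two cores, or the 4-chlorophenyl and 3-chloro-4-fluorophenyl groups, differ at all in this assay, as no compound shown gives a number there.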